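This account rests on a few compounds, and the source may have more. Where it says the series, first, only, none or still open, it means among the compounds named here.

Compound 1 `COc1ccc(-c2csc(NC(=O)COc3ccc(C(=O)c4ccc(C)cc4)cc3C)n2)cc1` and compound 2 `Cc1cc(C(=O)c2ccc(F)cc2)ccc1OCC(=O)Nc1nc(-c2ccccc2)cs1` share one core and were both tested in a functional assay on DLA cells (Mus musculus) for cytotoxicity, read by MTT assay, with a stated time of 48 h; a lower number here means a stronger inhibitor, a higher number a weaker inhibitor. In this assay compound 1 gives 17200 nM, and compound 2 gives 33300 nM. The number for compound 2 and the number for compound 1 lie within the usual scatter of each other, so no difference between them can be claimed. Compound 3 `COc1ccc(-c2csc(NC(=O)COc3ccc(C(=O)c4ccc(F)cc4)cc3C)n2)cc1` differs from compound 2 in one place: methoxy in place of hydrogen on an aromatic carbon. Going by the values given here, no measured pair shows this change alone, so its size here is unknown. Since compound 1, which already carries this methoxy group on the same ring, gives 17200 nM, the step from compound 2 to compound 3 is expected to stay within the scatter, with a 1.3-fold lower number from compound 2 to compound 3 (0.12 log units; within the scatter) as the estimated step. Compound 3 is therefore expected to give about 25000 nM in this assay, estimated between 8000 nM and 75000 nM.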

Compound 3, half-maximal inhibitory concentration: 5400 nM
Beside the measured number, compound 3's estimate is 4.6-fold (0.67 log units) above it, and the stated range ends above it.
By their numbers in this assay, from the lowest: compound 3; then compounds 1 and 2 (each within the scatter of the next).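

The change from phenyl to 4-methoxyphenyl, with the fluoro group held in place, gives a 6.2-fold lower number from compound 2 to compound 3 (0.79 log units; beyond the scatter) and so has a real effect at this position, something compounds 1 and 2 could not show because they differ in two places at once. The other place matters too: with the 4-methoxyphenyl group held in place, fluoro in place of methyl gives a 3.2-fold lower number from compound 1 to compound 3 (0.50 log units; beyond the scatter) and leaves compound 3 as the strongest inhibitor of the three. Nothing shown here explains why either change lowers the number.

From the compounds shown here alone, it remains open whether the methoxy group would bring a similar step with methyl in place of the fluoro group. Going by these compounds, it is also open how a hydroxy group or an amine at the same ring position would compare with methoxy.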